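Isopropyl for methoxypropyl on a reversed-amide analogue

The compounds below may be only part of what the source reports. "The series", "measured", "known", "first", "only" and "open" are said of these compounds alone.

Compound 1, `CCCn1cc(-c2ccc(NC(=O)c3cn(CC4CCOCC4)cc(-c4ccc(F)cc4)c3=O)cc2)c2c(N)ncnc21`, and compound 2, `Cn1cc(-c2ccc(NC(=O)c3cn(CC4CCOCC4)cc(-c4ccc(F)cc4)c3=O)c(F)c2)c2c(N)ncnc21`, carry the amide in one sense; in an assay on isolated protein for inhibition of tyrosine-protein kinase receptor UFO (Homo sapiens), read by ELISA (a higher number here means a weaker inhibitor, a lower number a stronger inhibitor), compound 1 gives 1.8 nM and compound 2 gives 0.2 nM. Compound 3, `COCCCn1cc(C(=O)Nc2ccc(-c3cn(C)c4ncnc(N)c34)cc2)c(=O)c(-c2ccc(F)cc2)c1`, carries the amide in the reverse sense. In this assay compound 3 reports only a limit, > 10 nM, so no number is known for it (the limit of > 10 nM in this assay, at which 1 of the 3 values shown sits). Compound 4, `CC(C)n1cc(C(=O)Nc2ccc(-c3cn(C)c4ncnc(N)c34)cc2)c(=O)c(-c2ccc(F)cc2)c1`, differs from compound 3 in one place: isopropyl in place of 3-methoxypropyl on an aromatic nitrogen. Going by the values given here, no measured pair reports the effect of this change, so the step is expected to be small, within the scatter, in either direction. Compound 4 is therefore expected to remain weak, with an estimated value of 25 nM, between 6 nM and 120 nM. The expected step is a step that the limit leaves unreadable from compound 3 to compound 4.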

Compound 4, half-maximal inhibitory concentration: 0.4 nM
Compound 4: middle estimate off by 63-fold (1.80 log units), on the high side, outside the stated range (below it).
By their numbers in this assay, from the lowest: compounds 2 and 4 (each within the scatter of the next); then compound 1. At a limit, above all of these: compound 3.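

On this aromatic nitrogen the substituent matters strongly: in this assay, isopropyl in place of 3-methoxypropyl gives an at least 25-fold lower number from compound 3 to compound 4 (1.39 log units; beyond the scatter). With this amide sense, compound 4 reaches 0.4 nM, so the weak reading of compound 3 does not hold for every compound sharing that amide. The step remains a bound, since the value for compound 3 is a limit: the limit of > 10 nM in this assay, at which 1 of the 4 values shown sits.

The compounds shown do not separate the loss of the ether oxygen from the shortening and branching of the chain. Nor do they show how cyclopropyl or a longer alkyl chain on this nitrogen would read.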